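The source may hold more compounds than are shown below. What is called first, only, known or untested is meant among the compounds shown, and "the series" means these compounds.

Working notes on the series sharing the core of compound 1 `CC(=O)N1N=C(c2ccc3ccccc3c2)OC1c1ccccc1`. In a functional assay on HepG2 cells (Homo sapiens) for antiproliferative activity, read by MTT assay, with a stated time of 48 h (on this read-out lower numbers stand for stronger inhibition and higher numbers for weaker inhibition), compound 1 gives 2.11 ug/mL, compound 2 `CC(=O)N1N=C(c2ccc3ccccc3c2)OC1c1ccc(Br)cc1` gives 2.08 ug/mL and compound 3 `CC(=O)N1N=C(c2ccc3ccccc3c2)OC1c1ccc(Cl)cc1` gives 1.88 ug/mL. Compound 3 stands with the other two, with a 1.1-fold lower number from compound 1 to compound 3 (0.05 log units; within the scatter) and a 1.1-fold lower number from compound 2 to compound 3 (0.04 log units; within the scatter). Compound 4 `CC(=O)N1N=C(c2ccc3ccccc3c2)OC1c1ccccc1F` follows from compound 3 by 2-fluorophenyl in place of 4-chlorophenyl on a saturated ring carbon. The steps above bear on it, together with a 1.0-fold lower number from compound 1 to compound 2 (0.01 log units; within the scatter). Within the data shown here, none of them leaves the scatter, although no measured compound carries 2-fluorophenyl. No step beyond the scatter is therefore expected in this assay. The expected change is a 1.1-fold higher number from compound 3 to compound 4 (0.03 log units; within the scatter). For compound 4 the estimated value is 2 ug/mL, with an expected range of 1.1 ug/mL to 3.6 ug/mL.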

Compound 4, half-maximal inhibitory concentration: 3.36 ug/mL
Compound 4: the middle estimate sits 1.7-fold (0.23 log units) below what was measured, within the range that was stated.
By their numbers in this assay, from the lowest: compounds 3, 2, 1 and 4 (each within the scatter of the next).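

In this assay the 2-fluorophenyl group gives a 1.6-fold higher number from compound 1 to compound 4 (0.20 log units; within the scatter), along with a 1.6-fold higher number from compound 2 to compound 4 (0.21 log units; within the scatter) and a 1.8-fold higher number from compound 3 to compound 4 (0.25 log units; within the scatter), and all three steps lie within the scatter. The saturated ring carbon therefore carries 2-fluorophenyl as well as phenyl, 4-bromophenyl and 4-chlorophenyl without any step leaving the scatter. No evidence on hand gives a reason for the size of these steps. Still open, on these data alone, is whether an amine or a carboxylic acid on this phenyl ring would leave the scatter. Also open, as far as these compounds go, is whether a longer chain in place of the phenyl ring would do so.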